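A few compounds are considered here, and "the series" means these few. Any claim that something is new, unique, unknown or untested is made for them only; others in the source may bear on it.

Three compounds have values so far in an ADME assay on HEL cells (Homo sapiens) for cytotoxicity (on this read-out lower numbers stand for higher toxicity in this test and higher numbers for lower toxicity in this test), and they are these

- Compound 1 `C/C(=N\NC(=O)COc1cccc2ccccc12)c1ccccc1` gives 20 ug/mL
- Compound 2 `COc1cc(/C=N/NC(=O)COc2cccc3ccccc23)cc(OC)c1OC` gives 47.9 ug/mL
- Compound 3 `O=C(COc1cccc2ccccc12)N/N=C/c1cccc(Br)c1` gives 48.6 ug/mL

Compound 1 has the lowest number of the three, and both of the others lie above it by more than the usual scatter. In this assay this makes compound 1 the most toxic of the set. Compound 4 `C/C(=N\NC(=O)COc1cccc2ccccc12)c1ccc(O)cc1` keeps the rest of compound 1 and changes one place, phenyl to 4-hydroxyphenyl hydroxy in place of hydrogen on an aromatic carbon with hydroxy in place of hydrogen on an aromatic carbon, para to a large group. For the measured compounds named here, no measured pair shows this change, so its size can only be judged loosely. A small upward move, within the scatter, is expected. The estimated change is a 1.4-fold higher number from compound 1 to compound 4 (0.15 log units; within the scatter) and it remains uncertain. For compound 4 the expected value is 28 ug/mL with an estimated range from 11 ug/mL to 70 ug/mL in this assay.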

Compound 4, half-maximal cytotoxic concentration: 11.1 ug/mL
For compound 4 the middle estimate is 2.5-fold (0.40 log units) above the measured one; the range from low to high includes it.
By their numbers in this assay, from the lowest: compounds 4 and 1 (each within the scatter of the next); then compounds 2 and 3 (each within the scatter of the next).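

In this assay, for the compounds shown here, placing hydroxy in place of hydrogen on an aromatic carbon, para to a large group, gives a 1.8-fold lower number from compound 1 to compound 4 (0.26 log units; within the scatter) and is the first one-place step available in this set. At this position, then, the added hydroxy group produces no step beyond the usual scatter, so compounds 1 and 4 cannot be told apart in this test. Nothing measured here gives a reason for this result.

On these data alone, whether an amine or a carboxylic acid at this same position would produce a step beyond the scatter remains open. The same applies to a longer chain ending in hydroxy.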